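Neopentyloxy in Place of Pentyloxy: Expected Potency

The compounds below may be only part of what the source reports. "The series", "measured", "known", "first", "only" and "open" are said of these compounds alone.

The set comprises compound 1 `Cc1cc(CN/C(S)=N/Cc2ccc(NS(C)(=O)=O)cc2)c(COC(=O)C(C)(C)C)cc1C`, compound 2 `CCCCOc1cc(C(C)(C)C)ccc1C/N=C(\S)NCc1ccc(NS(C)(=O)=O)cc1` and compound 3 `CCCCCOc1cc(C(C)(C)C)ccc1C/N=C(\S)NCc1ccc(NS(C)(=O)=O)cc1`. In a functional assay for inhibition of Vanilloid receptor (Rattus norvegicus) (a lower number here means a stronger inhibitor, a higher number a weaker inhibitor), compound 1 gives 70000 nM, compound 2 gives 60 nM and compound 3 gives 70 nM. Compound 3 thus stands second highest of the three numbers. The step of a 1.2-fold higher number from compound 2 to compound 3 (0.07 log units; within the scatter) lies within the scatter, whereas compound 1 sits far above compound 3. Compound 4 `CC(C)(C)COc1cc(C(C)(C)C)ccc1C/N=C(\S)NCc1ccc(NS(C)(=O)=O)cc1` has not yet been measured. It differs from compound 3 by tert-butyl in place of butyl on a saturated chain carbon bound to an oxygen on an aromatic ring; cut one bond further out, the same difference reads pentyl to neopentyl, or pentyloxy to neopentyloxy. For the measured compounds named here, only one measured step bears on this change: a 1.2-fold higher number from compound 2 to compound 3 (0.07 log units; within the scatter), which shows that adding one methyl along the chain leaves the number unchanged within the scatter. Going by the values given here, no measured pair tests branching on the saturated chain carbon bound to the oxygen on the aromatic ring, so the expectation rests on that single tolerance and carries a wide range. Compound 4 is therefore expected to show a 1.4-fold higher number from compound 3 to compound 4 (0.15 log units; within the scatter), that is no step beyond the scatter in either direction. Compound 4 is estimated at 100 nM, within 35 nM to 300 nM.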

Compound 4, half-maximal inhibitory concentration: 60 nM
Compound 4: the middle estimate sits 1.7-fold (0.22 log units) above what was measured, and the stated range covers the measured number.
By their numbers in this assay, from the lowest: compounds 2, 4 and 3 (each within the scatter of the next); then compound 1.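

The branched chain gives the first test of this position that goes beyond adding a methyl along a straight chain, and this assay shows a 1.2-fold lower number from compound 3 to compound 4 (0.07 log units; within the scatter) when tert-butyl takes the place of butyl on a saturated chain carbon bound to an oxygen on an aromatic ring. Set against the shorter chain, the neopentyloxy group shows no change at the digits printed from compound 2 to compound 4 (within the scatter) and so compounds 2, 3 and 4 form a group of three chains whose numbers all lie within the scatter of one another, which means that this position accepts a change in chain shape as well as in chain length among these compounds. No measurement offered here gives a reason for this tolerance of the chain shape.

The compounds shown leave open how far this tolerance reaches, for instance with a longer chain such as octyloxy or with a cyclohexylmethyl group on the oxygen. They also leave open whether the number would hold if the chain ended in an amine or a carboxylic acid.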